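Methoxy for fluoro on the aryl of compound 2

The source may report more compounds than this note shows. Statements on the series, on what has been measured and on what is new or still open speak of the compounds shown alone.

Compound 1 `COc1ccccc1N1CCN(CCCNC(=O)NN(Cc2cccc(F)c2)c2ccc(F)cc2)CC1`: 3.8 nM
Compound 2 `COc1ccccc1N1CCN(CCCNC(=O)NN(Cc2ccc(C#N)cc2)c2ccc(F)cc2)CC1`: 15 nM
Compound 3 `COc1ccccc1N1CCN(CCCNC(=O)NN(Cc2ccc(-c3ccccc3)cc2)c2ccc(F)cc2)CC1`: 5.9 nM

Of the compounds shown here, three sharing one core have been measured in an assay on CHO cells for displacement of a labelled ligand from D(4) dopamine receptor (Homo sapiens), read by radioligand binding; on this read-out higher numbers stand for weaker inhibition and lower numbers for stronger inhibition. Compound 1 gives 3.8 nM, compound 2 gives 15 nM and compound 3 gives 5.9 nM. Compound 2 stands at the highest number of the three, with both of its steps beyond the scatter: a 3.9-fold higher number from compound 1 to compound 2 (0.60 log units; beyond the scatter) and a 2.5-fold lower number from compound 2 to compound 3 (0.41 log units; beyond the scatter). The step of a 1.6-fold higher number from compound 1 to compound 3 (0.19 log units; within the scatter) stays within the scatter.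

Compound 4 `COc1ccc(N(Cc2ccc(C#N)cc2)NC(=O)NCCCN2CCN(c3ccccc3OC)CC2)cc1` is not yet measured. It differs from compound 2 in one place: methoxy in place of fluoro on an aromatic carbon. Among the measured compounds shown here, none of the measured steps touches this position. All three changes so far concern the group on the saturated chain carbon bound to the nitrogen on the aromatic ring, and the 4-fluorophenyl on that nitrogen is the same in compounds 1, 2 and 3. For the measured compounds named here, no measured step therefore bears directly on the change from compound 2 to compound 4, and the nearest ones, which moved the number only modestly, give no direction for it.

Compound 4 is accordingly expected to stay close to compound 2, with the step of a 1.2-fold lower number from compound 2 to compound 4 (0.06 log units; within the scatter) estimated to lie within or barely beyond the scatter. The estimate for compound 4 in this assay is 13 nM, with a range from 4 nM to 40 nM.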

Compound 4, inhibition constant: 16 nM
Estimate against measurement, compound 4: 1.2-fold (0.09 log units) below; the range from low to high includes it.
By their numbers in this assay, from the lowest: compounds 1 and 3 (each within the scatter of the next); then compounds 2 and 4 (each within the scatter of the next).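

Among the compounds shown here, compound 4 gives the first reading at the aryl group on the nitrogen, which is 4-fluorophenyl in compounds 1, 2 and 3. In this assay, putting 4-methoxyphenyl there gives a 1.1-fold higher number from compound 2 to compound 4 (0.03 log units; within the scatter), so on this aromatic carbon, para to a large group, fluoro (1 heavy atom, 0 hydrogen-bond acceptors) and methoxy (2 heavy atoms, 1 hydrogen-bond acceptor) cannot be told apart, whereas the change on the saturated chain carbon gave a 3.9-fold higher number from compound 1 to compound 2 (0.60 log units; beyond the scatter), a step beyond the scatter. Nothing given here accounts for this flat result.

The reading rests on a single pair carrying the 4-cyanophenyl group, so the compounds shown do not tell whether the same swap would stay within the scatter alongside the 3-fluorophenyl of compound 1 or the 4-phenylphenyl of compound 3. They also leave open whether an amine, a carboxylic acid or a longer chain on this aromatic carbon would leave the number as flat as methoxy does.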